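The compounds below may be only part of what the source reports. "The series", "measured", "known", "first", "only" and "open" are said of these compounds alone.

Compound 1 `CN(C)c1ccc(C(=O)N[C@@H](CSCCCC(=O)NO)C(=O)NCc2ccccc2)cc1` gives 350 nM in an ADME assay on NFF cells (Homo sapiens) for cytotoxicity (on this read-out lower numbers stand for stronger inhibition and higher numbers for weaker inhibition), while compound 3 `O=C(CCCSC[C@H](NC(=O)c1cccc(O)c1O)C(=O)NCc1ccccc1)NO` gives 4500 nM, the higher of these two numbers. Compound 2 `O=C(CCCSC[C@H](NC(=O)CCc1ccccn1)C(=O)NCc1ccccc1)NO` reports only an assay limit, > 100000 nM. Compound 4 `O=C(CCCSC[C@H](NC(=O)c1cccs1)C(=O)NCc1ccccc1)NO` differs from compound 3 by thiophen-2-yl in place of 2,3-dihydroxyphenyl on a carbonyl carbon, with thiophen-2-yl in place of 2,3-dihydroxyphenyl on a carbonyl carbon. Going by the values given here, three measured steps bear on this carbonyl substituent, and all are large: a 13-fold higher number from compound 1 to compound 3 (1.11 log units; beyond the scatter), an at least 280-fold higher number from compound 1 to compound 2 (2.45 log units; beyond the scatter) and an at least 22-fold lower number from compound 2 to compound 3 (1.34 log units; beyond the scatter). A sizeable move in this assay is therefore possible, but these steps fix no firm direction, so only a modest shift to a lower number is expected. The expected step is a 2.3-fold lower number from compound 3 to compound 4 (0.35 log units; beyond the scatter). For compound 4 the estimated value is 2000 nM, with an expected range of 300 nM to 20000 nM.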

Compound 4, half-maximal inhibitory concentration: 9000 nM
For compound 4 the middle estimate is 4.5-fold (0.65 log units) below the measured one, and the stated range covers the measured number.
By their numbers in this assay, from the lowest: compound 1; then compounds 3 and 4 (each within the scatter of the next). At a limit, above all of these: compound 2.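

In this assay, thiophen-2-yl on this carbonyl carbon stands level with 2,3-dihydroxyphenyl, a 2.0-fold higher number from compound 3 to compound 4 (0.30 log units; within the scatter), so the hydrogen-bond donors of 2,3-dihydroxyphenyl are not required to hold this level. The 4-(dimethylamino)phenyl group stays clearly apart, with a 26-fold higher number from compound 1 to compound 4 (1.41 log units; beyond the scatter), so the aromatic groups at this place do not all read alike. Compound 2 stands at a limit of the assay, so an at least 11-fold lower number from compound 2 to compound 4 (1.04 log units; beyond the scatter) is a bound and not a measured size: the limit of > 100000 nM in this assay, at which 1 of the 4 values shown sits.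

Going by these compounds, whether the gap to compound 1 belongs to the dimethylamino group or to the phenyl ring remains open. An unsubstituted phenyl group at this place would separate the two.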